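Swapping Hydrogen for Fluoro on the Indole Side

The compounds below may be only part of what the source reports. "The series", "measured", "known", "first", "only" and "open" are said of these compounds alone.

- compound 1 `O=C(CN1CCN(C(=O)c2ccc(Cl)cc2)CC1)N1CCN(CCCc2c[nH]c3ccccc23)CC1`: 98200 nM
- compound 2 `O=C(CN1CCN(C(=O)c2cccc(Cl)c2)CC1)N1CCN(CCCc2c[nH]c3ccccc23)CC1`: 99100 nM
- compound 3 `O=C(CN1CCN(C(=O)c2ccccc2F)CC1)N1CCN(CCCc2c[nH]c3ccccc23)CC1`: 133000 nM

In an ADME assay on HEK293 cells (Homo sapiens) for cytotoxicity, read by MTT assay, with a stated time of 72 h (on this read-out lower numbers stand for stronger inhibition and higher numbers for weaker inhibition), compound 1 gives 98200 nM, and it cannot be separated from its two relatives. The measured steps are a 1.0-fold higher number from compound 1 to compound 2 (0.00 log units; within the scatter) and a 1.4-fold higher number from compound 1 to compound 3 (0.13 log units; within the scatter). The remaining comparison is a 1.3-fold higher number from compound 2 to compound 3 (0.13 log units; within the scatter). Taken together, the three compounds form a single group on this scale, with no order among them.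

Compound 4 `O=C(CN1CCN(C(=O)c2ccc(Cl)cc2)CC1)N1CCN(CCCc2c[nH]c3ccc(F)cc23)CC1` keeps most of compound 1 and changes it in one place: fluoro in place of hydrogen on an aromatic carbon. Put another way, 1H-indol-3-yl becomes 5-fluoro-1H-indol-3-yl. Among the measured compounds shown here, none of the measured steps makes this change. All three instead exchange the halogen-bearing phenyl group on the carbonyl carbon, so they bear on it only indirectly. They show that, across these three compounds, such exchanges left the number within the scatter, and the data say nothing directly about the new fluoro group.

With no evidence for a real shift in either direction, no change beyond the scatter is expected in this assay. The expected step is a 1.0-fold higher number from compound 1 to compound 4 (0.01 log units; within the scatter). For compound 4 the estimated value is 100000 nM, with an expected range from 50000 nM to 200000 nM.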

Compound 4, half-maximal inhibitory concentration: 44500 nM
Beside the measured number, compound 4's estimate is 2.2-fold (0.35 log units) above it; the whole stated range lies above it.
By their numbers in this assay, from the lowest: compound 4; then compounds 1, 2 and 3 (each within the scatter of the next).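

Within this assay, replacing one hydrogen to turn 1H-indol-3-yl into 5-fluoro-1H-indol-3-yl gives a 2.2-fold lower number from compound 1 to compound 4 (0.34 log units; beyond the scatter), a modest step but a real one on this scale. The earlier steps shown here, such as a 1.0-fold higher number from compound 1 to compound 2 (0.00 log units; within the scatter) and a 1.4-fold higher number from compound 1 to compound 3 (0.13 log units; within the scatter), changed only the phenyl group on the carbonyl carbon and stayed within the scatter, so they could not show that the other end of the molecule matters; this result shows that even a single added fluorine atom on this aromatic carbon can move the number beyond the scatter. No accompanying measurement accounts for this shift.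

Going by these compounds, it remains open whether the step belongs to fluoro in particular or would also appear with a chloro, methoxy or amino group on the same aromatic carbon. On these data alone, it is also open whether the same fluoro would give a similar step alongside the 3-chlorophenyl group of compound 2 or the 2-fluorophenyl group of compound 3.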